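The source may hold more compounds than are shown below. What is called first, only, known or untested is meant among the compounds shown, and "the series" means these compounds.

In a physicochemical assay for solubility, measured as kinetic solubility, with a stated time of 1 h, at pH 7.4 (on this read-out lower numbers stand for lower solubility and higher numbers for higher solubility), the measured compounds read as follows.

- compound 1 `CC(=O)NC1=NN(c2ccc(Cl)c(Cl)c2)CC1` gives 31000 nM
- compound 2 `N#CCCC(=O)NC1=NN(c2ccc(Cl)c(Cl)c2)CC1` gives 39000 nM
- compound 3 `O=C(NC1=NN(c2ccc(Cl)c(Cl)c2)CC1)c1cccnc1` gives 4000 nM

Compound 3 has the lowest number of the three, and both other compounds lie beyond the scatter above it. Compound 4 `O=C(NC1=NN(c2ccc(Cl)c(Cl)c2)CC1)c1cncnc1` has not been measured. It carries pyrimidin-5-yl in place of pyridin-3-yl on a carbonyl carbon.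

Two measured steps change the group at this same place: a 7.8-fold lower number from compound 1 to compound 3 (0.89 log units; beyond the scatter) and a 9.8-fold lower number from compound 2 to compound 3 (0.99 log units; beyond the scatter). Both are modest, and both bring in pyridin-3-yl in place of a non-ring group. For the measured compounds named here, neither exchanges one ring for another, so they are only a loose guide, and no measured pair shows this exact swap. In this assay a smaller step than those two is therefore expected, perhaps leaning upward, although nothing measured fixes the direction. The estimated change is a 1.5-fold higher number from compound 3 to compound 4 (0.18 log units; within the scatter). For compound 4 the expected value is 6000 nM, with an estimated range from 2000 nM to 16000 nM.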

Compound 4, solubility: 8000 nM
The estimate for compound 4 lay 1.3-fold (0.12 log units) below the measured number; low and high end bracket the measured number.
By their numbers in this assay, from the lowest: compounds 3 and 4 (each within the scatter of the next); then compounds 1 and 2 (each within the scatter of the next).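

In this assay, for the compounds shown here, this is the first exchange of one ring for another on the carbonyl carbon, and a 2.0-fold higher number from compound 3 to compound 4 (0.30 log units; within the scatter) stays within the scatter, so pyrimidin-5-yl and pyridin-3-yl cannot be told apart at this place. Compound 4 also falls beyond the scatter under both non-ring compounds, with a 3.9-fold lower number from compound 1 to compound 4 (0.59 log units; beyond the scatter) and a 4.9-fold lower number from compound 2 to compound 4 (0.69 log units; beyond the scatter) as the steps, so among these four compounds both rings read lower than the methyl and 2-cyanoethyl groups, and no compound goes against this. Nothing available explains these numbers.

On these data alone, how a plain phenyl ring, a saturated ring such as piperidine, or a ring bearing an amine or a carboxylic acid would read at this place remains open. So does the effect of any change elsewhere on the shared core, since all four compounds differ only at this one place.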